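Shifting the Fluorine on the Phenyl of a Piperazine Amide

The source may hold more compounds than are shown below. What is called first, only, known or untested is meant among the compounds shown, and "the series" means these compounds.

Compound 1 `CC(C(=O)N1CCN(c2ccccc2F)CC1)N1C(=O)CCC1=O` and compound 2 `CC(C(=O)N1CCN(c2ccc(F)cc2)CC1)N1C(=O)CCC1=O` share the same core and differ only in the fluorophenyl group on the ring nitrogen. In a functional assay on the whole organism (strain Swiss) with Mus musculus as the target, in the maximal electroshock model, with a stated time of 0.25 h, at a dose of 300 mg/kg by the intraperitoneal route (a lower number here means a weaker effect, a higher number a stronger effect of the compound at the dose given), compound 1 gives 100%. In this assay compound 2 gives 100%. The step of no change at the digits printed from compound 1 to compound 2 (within the scatter) shows that exchanging one fluorophenyl for another on this nitrogen left the read-out where it was. Compound 2 therefore stands level with compound 1 on the numbers in hand; its nearest neighbour is compound 1, and the two cannot be told apart within the scatter.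

Compound 3 `CC(C(=O)N1CCN(c2cccc(F)c2)CC1)N1C(=O)CCC1=O` is the third member of this set and differs from compound 2 by 3-fluorophenyl in place of 4-fluorophenyl on an amine nitrogen in a ring. Among the compounds with values here, the one measured step that bears on such a change is no change at the digits printed from compound 1 to compound 2 (within the scatter), which was a change of the same kind, another fluorophenyl in place of a fluorophenyl, and it brought no shift beyond the scatter. On that basis compound 3 is expected to differ from compound 2 by no change at the digits printed from compound 2 to compound 3 (within the scatter), that is, no step beyond the scatter. For compound 3 the estimated value in this assay is 100%, with an expected range from 75% to 100%.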

Compound 3, a percentage reported as activity, at one dose (the size of the read-out at that dose, not a potency): 100%
For compound 3 middle estimate and measured number coincide at the digits printed; the measured number falls inside the stated range.
By their numbers in this assay, from the lowest: compounds 1, 2 and 3 (each within the scatter of the next).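

In this assay the 3-fluorophenyl group gives no change at the digits printed from compound 2 to compound 3 (within the scatter), and set against the 2-fluorophenyl group it gives no change at the digits printed from compound 1 to compound 3 (within the scatter). The earlier pair covered only the 2-fluorophenyl and 4-fluorophenyl groups, whereas all three fluorophenyl groups have now been read on this amine nitrogen in a ring, and at this single dose and time the read-out does not separate any of them. Nothing in the data on hand explains why the read-out stays the same across these three groups.

The read-out at one dose is not a potency, so the compounds shown leave open whether the three would separate at a smaller dose. They also leave open what the fluorine contributes at this place, a question that a plain phenyl, a chlorophenyl or a methoxyphenyl group on the same nitrogen, with the shared core unchanged, would address.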